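Replacing 4-methoxyphenyl with thiophen-2-yl: compound 3 to compound 4

The compounds below may be only part of what the source reports. "The series", "measured", "known", "first", "only" and "open" are said of these compounds alone.

Compound 1 `COc1cc(C(=O)c2sc(-c3ccc(Cl)cc3)cc2N)cc(OC)c1OC` gives 93 nM
Compound 2 `COc1cc(C(=O)c2sc(-c3ccsc3)cc2N)cc(OC)c1OC` gives 12 nM
Compound 3 `COc1ccc(-c2cc(N)c(C(=O)c3cc(OC)c(OC)c(OC)c3)s2)cc1` gives 45 nM

These three numbers come from a functional assay on L1210 cells (Mus musculus) for antiproliferative activity; a lower number here means a stronger inhibitor, a higher number a weaker inhibitor. Compound 3, at 45 nM, stands in the middle of them, with compound 1 its nearest neighbour and compound 2 its furthest, and both gaps lie beyond the scatter.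

Compound 4 `COc1cc(C(=O)c2sc(-c3cccs3)cc2N)cc(OC)c1OC` has not yet been measured. It differs from compound 3 in a single place: thiophen-2-yl in place of 4-methoxyphenyl on an aromatic carbon. The nearest evidence is a 3.8-fold higher number from compound 2 to compound 3 (0.57 log units; beyond the scatter), where 4-methoxyphenyl takes the place of thiophen-3-yl. Read in reverse, this suggests that a thiophene in place of 4-methoxyphenyl could lower the number. The step of a 7.8-fold lower number from compound 1 to compound 2 (0.89 log units; beyond the scatter) also ends at the thiophen-3-yl compound, though it starts from 4-chlorophenyl. The step of a 2.1-fold lower number from compound 1 to compound 3 (0.32 log units; beyond the scatter) only exchanges chloro for methoxy, so it bears on the question less directly. Among the measured compounds shown here, no compound carrying thiophen-2-yl has been measured, so carrying over the result for thiophen-3-yl remains uncertain. For the measured compounds named here, a modest drop is therefore expected, somewhat smaller than the one the thiophen-3-yl comparison would imply, and the expected step is a 2.3-fold lower number from compound 3 to compound 4 (0.35 log units; beyond the scatter). The estimate for compound 4 is 20 nM in this assay, with an expected range from 7 nM to 60 nM.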

Compound 4, half-maximal inhibitory concentration: 9.8 nM
Compound 4: middle estimate off by 2.0-fold (0.31 log units), on the high side; the range from low to high includes it.
By their numbers in this assay, from the lowest: compounds 4 and 2 (each within the scatter of the next); then compound 3; then compound 1.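

In this assay, thiophen-2-yl at this position, on the aromatic carbon next to the ring sulfur, gives a 4.6-fold lower number from compound 3 to compound 4 (0.66 log units; beyond the scatter) and a 9.5-fold lower number from compound 1 to compound 4 (0.98 log units; beyond the scatter), so the advantage seen earlier for thiophen-3-yl over both substituted phenyl groups is not confined to that one thiophene. The new comparison between the two thiophenes, a 1.2-fold lower number from compound 2 to compound 4 (0.09 log units; within the scatter), lies within the scatter, so moving the point of attachment from the 3-position to the 2-position of the thiophene makes no difference that this assay can resolve, and the two compounds cannot be ranked. Across these four compounds, the two carrying a thiophene both give lower numbers than the two carrying a substituted phenyl, with no compound going against that split, but nothing presented here explains the gap.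

On these data alone, what remains open is whether this split reflects the thiophene ring itself or the absence of the chloro or methoxy substituent, a question that an unsubstituted phenyl group at the same carbon would address. As far as these compounds go, it is also open whether other five-membered rings, such as furan-2-yl, or a non-aromatic group, such as a morpholine amine or a short alkyl chain, would fit the same pattern.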